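A few compounds are considered here, and "the series" means these few. Any claim that something is new, unique, unknown or untested is made for them only; others in the source may bear on it.

Measured compounds:
- compound 1 `COc1cccc(/C=C/C(=O)C(=Cc2ccc(F)cc2)C(=O)/C=C/c2cccc(OC)c2OC)c1OC`: 340 nM
- compound 2 `COc1cccc(/C=C/C(=O)C(=Cc2cc(OC)c(OC)c(OC)c2)C(=O)/C=C/c2cccc(OC)c2OC)c1OC`: 230 nM
- compound 3 `COc1cc(C=C(C(=O)/C=C/c2cccc(OC)c2OC)C(=O)/C=C/c2cccc(OC)c2OC)cc(Br)c1O`: 200 nM

In a functional assay on A549 cells (Homo sapiens) for antiproliferative activity, read by sulforhodamine B assay, with a stated time of 48 h (a lower number here means a stronger inhibitor, a higher number a weaker inhibitor), these three compounds lie close together. Compound 2 is separated from the other two only by a 1.5-fold lower number from compound 1 to compound 2 (0.17 log units; within the scatter) and a 1.2-fold lower number from compound 2 to compound 3 (0.06 log units; within the scatter).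

Compound 4 `COc1cc(C=C(C(=O)/C=C/c2cccc(OC)c2OC)C(=O)/C=C/c2cccc(OC)c2OC)cc(OC)c1O` differs from compound 2 by a single change, hydrogen in place of methyl on an oxygen on an aromatic ring. This turns 3,4,5-trimethoxyphenyl into 4-hydroxy-3,5-dimethoxyphenyl.

Going by the values given here, no measured step makes this change alone. The closest is the step to compound 3, which carries 3-bromo-4-hydroxy-5-methoxyphenyl, and a 1.7-fold lower number from compound 1 to compound 3 (0.23 log units; within the scatter) is also small. No step beyond the scatter is therefore expected in this assay.

The expected step is a 1.1-fold lower number from compound 2 to compound 4 (0.04 log units; within the scatter).

For compound 4 the estimated value is 210 nM, with an expected range of 100 nM to 450 nM.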

Compound 4, half-maximal inhibitory concentration: 240 nM
Compound 4: middle estimate off by 1.1-fold (0.06 log units), on the low side, within the range that was stated.
By their numbers in this assay, from the lowest: compounds 3, 2, 4 and 1 (each within the scatter of the next).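

In this assay, hydrogen in place of methyl on an oxygen on an aromatic ring, which turns methoxy into hydroxy, stays within the scatter (a 1.0-fold higher number from compound 2 to compound 4 (0.02 log units; within the scatter)). The other two steps to compound 4 are also within the scatter: methoxy in place of bromo on an aromatic carbon (a 1.2-fold higher number from compound 3 to compound 4 (0.08 log units; within the scatter)), and 4-hydroxy-3,5-dimethoxyphenyl in place of 4-fluorophenyl (a 1.4-fold lower number from compound 1 to compound 4 (0.15 log units; within the scatter)). No independent measurement accompanies these numbers to explain them. Still open, on these data alone, is whether an amine or a carboxylic acid in place of the hydroxy would leave the number in this same range.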